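The compounds below may be only part of what the source reports. "The series", "measured", "known", "first", "only" and "open" are said of these compounds alone.

Going by the values given here, in an assay on CHO cells for displacement of a labelled ligand from prostaglandin E2 receptor EP4 subtype (Mus musculus), read by scintillation counting, with a stated time of 60 min (a higher number here means a weaker inhibitor, a lower number a stronger inhibitor), compound 2 `O=C(O)c1csc(SCCN2C(=O)CC[C@@H]2/C=C/[C@@H](O)Cc2cccc(-c3ccc(Cl)cc3)c2)n1` gives 0.81 nM, the higher of the two numbers measured so far. Compound 1 `O=C(O)CCCSCCN1C(=O)CC[C@@H]1/C=C/[C@@H](O)Cc1cccc(-c2nc3ccccc3s2)c1` gives 0.36 nM in this assay, a lower number than compound 2 by a gap beyond the usual scatter. Compound 3 `Cc1ccc2oc(-c3cccc(C[C@H](O)/C=C/[C@H]4CCC(=O)N4CCSc4nc(C(=O)O)cs4)c3)nc2c1` differs from compound 2 by 5-methyl-1,3-benzoxazol-2-yl in place of 4-chlorophenyl on an aromatic carbon. Among the compounds with values here, no measured pair isolates this change, so its effect in this assay cannot be read from the data. The step is expected to be small, toward a lower number or none beyond the scatter, amounting to a 1.6-fold lower number from compound 2 to compound 3 (0.21 log units; within the scatter). Compound 3 is therefore estimated at 0.5 nM in this assay, with a range from 0.15 nM to 1.6 nM.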

Compound 3, inhibition constant: 0.21 nM
Compound 3: middle estimate off by 2.4-fold (0.38 log units), on the high side, within the range that was stated.
By their numbers in this assay, from the lowest: compounds 3 and 1 (each within the scatter of the next); then compound 2.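

In this assay, 5-methyl-1,3-benzoxazol-2-yl in place of 4-chlorophenyl on this aromatic carbon gives a 3.9-fold lower number from compound 2 to compound 3 (0.59 log units; beyond the scatter) as a modest step beyond the scatter. This position, meta to a large group, therefore accepts a fused two-ring group with two hydrogen-bond acceptors and gains from the exchange. Nothing at hand explains the gain. As far as these compounds go, whether the methyl contributes to the step stays open. So does how a 1,3-benzoxazol-2-yl without the methyl, or with a methoxy group in its place, would read here.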